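The source may report more compounds than this note shows. Statements on the series, on what has been measured and on what is new or still open speak of the compounds shown alone.

Measured compounds in a functional assay on HL-60 cells (Homo sapiens) for antiproliferative activity, read by MTT assay, with a stated time of 72 h; on this read-out lower numbers stand for stronger inhibition and higher numbers for weaker inhibition:
compound 1 `NC1=NC2(CCOCC2)N(OCCCOc2ccc(Cl)c(Cl)c2)C(N)=N1`: 1240 nM
compound 2 `NC1=NC2(CCSCC2)N(OCCCOc2ccc(Br)cc2)C(N)=N1`: 350 nM
compound 3 `NC1=NC2(CCOCC2)N(OCCCOc2cccc(Br)c2)C(N)=N1`: 560 nM

Compound 1 gives the highest number of the three in this assay; its nearest neighbour is compound 3, and compound 2 lies furthest from it. The two known values of compound 2 and compound 3 both sit well below that of compound 1.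

The unmeasured compound 4 `NC1=NC2(CCOCC2)N(OCCCOc2ccc(Br)cc2)C(N)=N1` differs from compound 1 in a single place: 4-bromophenyl in place of 3,4-dichlorophenyl on an oxygen on a saturated carbon

Among the compounds with values here, one measured step bears on this change. Going from compound 1 to compound 3, where a bromophenyl likewise replaces the 3,4-dichlorophenyl on the same oxygen, the number fell by a 2.2-fold lower number from compound 1 to compound 3 (0.35 log units; beyond the scatter). Compound 2 carries the same 4-bromophenyl as compound 4 but differs from compound 1 in a second place as well, so its value only indicates that a 4-bromophenyl is compatible with a number lower than that of compound 1. On this basis a modest decrease from compound 1 to compound 4 is expected, of about the size seen toward compound 3, namely a 2.5-fold lower number from compound 1 to compound 4 (0.39 log units; beyond the scatter). Compound 4 is therefore estimated at 500 nM, with a range from 250 nM to 1000 nM.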

Compound 4, half-maximal inhibitory concentration: 310 nM
Beside the measured number, compound 4's estimate is 1.6-fold (0.21 log units) above it, and the stated range covers the measured number.
By their numbers in this assay, from the lowest: compounds 4, 2 and 3 (each within the scatter of the next); then compound 1.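

In this assay, 4-bromophenyl in place of 3,4-dichlorophenyl on the oxygen gives a step beyond the scatter (a 4.0-fold lower number from compound 1 to compound 4 (0.60 log units; beyond the scatter)), so a second bromophenyl compound now lies clearly under compound 1, alongside the one seen earlier (a 2.2-fold lower number from compound 1 to compound 3 (0.35 log units; beyond the scatter)). The new comparison also tests where the bromine sits on the phenyl, and the two bromophenyl compounds cannot be told apart in this assay, since the step separating them stays within the scatter (a 1.8-fold lower number from compound 3 to compound 4 (0.26 log units; within the scatter)). Within this small set, then, the change that registers is leaving the 3,4-dichlorophenyl, not moving from 3-bromophenyl to 4-bromophenyl, and no measurement shown here offers any explanation for either result.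

On these data alone, what remains open is how an unsubstituted phenyl, a 4-chlorophenyl or a phenyl carrying an amine or a carboxylic acid would compare with compound 4 at this same place. Also open, as far as these compounds go, is whether a longer chain on the oxygen would preserve the number, and whether the order seen here would hold outside this assay.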